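Piperidin-1-yl in place of azetidin-1-yl on a carbonyl carbon

The source may report more compounds than this note shows. Statements on the series, on what has been measured and on what is new or still open speak of the compounds shown alone.

Compound 1 `C=CC(=O)NCCOc1ccc(Oc2c(-c3ccc(F)cc3)sc3cc(O)ccc23)cc1` – > 25000 nM (a limit)
Compound 2 `CN(C)C(=O)/C=C/CNCCOc1ccc(Oc2c(-c3ccc(F)cc3)sc3cc(O)ccc23)cc1` – 11900 nM
Compound 3 `O=C(/C=C/CNCCOc1ccc(Oc2c(-c3ccc(F)cc3)sc3cc(O)ccc23)cc1)N1CCC1` – 6560 nM

All three values come from a functional assay on Ishikawa cells (Homo sapiens) for antiproliferative activity, read by CCK-8 assay, with a stated time of 48 h; a higher number here means a weaker inhibitor, a lower number a stronger inhibitor. Compound 1 has only a limit, > 25000 nM. Of the two true numbers, compound 3 at 6560 nM lies within the scatter of compound 2 at 11900 nM.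

Compound 4 `O=C(/C=C/CNCCOc1ccc(Oc2c(-c3ccc(F)cc3)sc3cc(O)ccc23)cc1)N1CCCCC1` carries piperidin-1-yl in place of azetidin-1-yl on a carbonyl carbon. The nearest measured change, at this same carbonyl carbon, is a 1.8-fold lower number from compound 2 to compound 3 (0.26 log units; within the scatter), and it stays within the scatter. The steps of an at least 2.1-fold lower number from compound 1 to compound 2 (0.32 log units; beyond the scatter) and an at least 3.8-fold lower number from compound 1 to compound 3 (0.58 log units; beyond the scatter) replace vinylcarbonyl on an amine nitrogen, and so bear little on this change. In this assay no shift beyond the scatter is therefore expected, and the expected step is a 1.1-fold higher number from compound 3 to compound 4 (0.03 log units; within the scatter). The estimated value for compound 4 is 7000 nM, with an expected range of 3000 nM to 16000 nM.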

Compound 4, half-maximal inhibitory concentration: 8430 nM
The estimate for compound 4 lay 1.2-fold (0.08 log units) below the measured number; the range from low to high includes it.
By their numbers in this assay, from the lowest: compounds 3, 4 and 2 (each within the scatter of the next). At a limit, above all of these: compound 1.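

In this assay, piperidin-1-yl on this carbonyl carbon does not separate from azetidin-1-yl or dimethylamino: a 1.3-fold higher number from compound 3 to compound 4 (0.11 log units; within the scatter), and a 1.4-fold lower number from compound 2 to compound 4 (0.15 log units; within the scatter). With 3-((piperidin-1-yl)carbonyl)prop-2-en-1-yl in place of vinylcarbonyl on the amine nitrogen, the result is an at least 2.9-fold lower number from compound 1 to compound 4 (0.47 log units; beyond the scatter), the third such step beyond the scatter. Compound 1 stands only at a limit: the limit of > 25000 nM in this assay, at which 1 of the 4 values shown sits.

The compounds shown leave open whether morpholin-4-yl or a carboxylic acid at this carbonyl carbon would stand apart from these three amides. They also leave open what a longer chain in place of prop-2-en-1-yl would do.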